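Removing a Methoxy Group from a Melanoma Growth Inhibitor

This account rests on a few compounds, and the source may have more. Where it says the series, first, only, none or still open, it means among the compounds named here.

Measured compounds:
compound 1, `Nc1cc(N)c2nc(-c3ccccc3)c(Oc3ccc(F)cc3)nc2c1`, < 100000 nM
compound 2, `COc1cc(CNc2nc3cc(N)cc(N)c3nc2-c2ccccc2)cc(OC)c1OC`, < 50200 nM
compound 3, `COc1ccc(CNc2nc3cc(N)cc(N)c3nc2-c2ccccc2)cc1OC`, 30200 nM

For the measured compounds named here, in a functional assay on SK-MEL-2 cells (Homo sapiens) for inhibition, read by sulforhodamine B assay, with a stated time of 48 h (on this read-out lower numbers stand for stronger inhibition of growth and higher numbers for weaker inhibition of growth), compound 3 gives 30200 nM, the only full number among the three. For compound 1 the value < 100000 nM is a limit of the assay, not a number. For compound 2 the value < 50200 nM is likewise a limit, as the evidence the limit of < 50200 nM in this assay, at which 1 of the 3 values shown sits, shows. The step that the limit leaves unreadable from compound 2 to compound 3 therefore cannot be read.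

Compound 4, `COc1ccc(CNc2nc3cc(N)cc(N)c3nc2-c2ccccc2)cc1`, differs from compound 3 by hydrogen in place of methoxy on an aromatic carbon. No readable step bears on this change, so nothing beyond the scatter is expected in either direction. Compound 4 is expected to give 30000 nM, between 10000 nM and 90000 nM, meaning a step of a 1.0-fold lower number from compound 3 to compound 4 (0.00 log units; within the scatter).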

Compound 4, concentration for total growth inhibition: 28800 nM
Beside the measured number, compound 4's estimate is 1.0-fold (0.02 log units) above it; the range from low to high includes it.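

Taking this methoxy off the ring, so that 3,4-dimethoxyphenyl becomes 4-methoxyphenyl, gives a 1.0-fold lower number from compound 3 to compound 4 (0.02 log units; within the scatter) in this assay, the first readable figure for this swap, as the same swap from compound 2 to compound 3 cannot be read. At this position, then, hydrogen and methoxy give growth inhibition within the usual scatter of each other. Nothing among the measurements shown accounts for this result.

From the compounds shown here alone, whether a chlorine, an amine or a carboxylic acid at this position would shift the number stays open. So does the effect of replacing the remaining methoxy with hydrogen.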